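The source may report more compounds than this note shows. Statements on the series, on what has been measured and on what is new or still open speak of the compounds shown alone.

Measured compounds:
Compound 1, `COc1cc(OCc2cnc(Cl)c(Cl)c2)ccc1CNCc1ccncc1`: 400 nM
Compound 2, `COc1cc(CNCCCN(C)C)ccc1OCc1ccc(Cl)nc1`: 5000 nM
Compound 3, `COc1cc(CNCc2ccncc2)ccc1OCc1ccccc1F`: 5100 nM

These three compounds were tested in a functional assay on HeLa cells (Homo sapiens) for inhibition, with a stated time of 72 h; a lower number here means that less compound is needed, a higher number that more compound is needed for the effect. Compound 2 gives 5000 nM, the second highest of the three numbers. Its nearest neighbour is compound 3, whose 5100 nM lies within the scatter of compound 2, so the two cannot be told apart. Compound 1, with 400 nM, stands well apart, beyond the scatter, and needs far less compound than compound 2.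

The next compound, compound 4, `COc1cc(CNCc2cccnc2)ccc1OCc1ccc(Cl)nc1`, has not yet been measured in this assay. It differs from compound 2 in one place: pyridin-3-yl in place of 2-(dimethylamino)ethyl on a saturated chain carbon bound to an amine nitrogen. The open chain ending in an amine is thus exchanged for an aromatic ring that carries a nitrogen atom.

Going by the values given here, no measured pair here shows this exact exchange, so its effect on this assay cannot be read off directly. Compound 3, which also carries a ring-bearing chain at this position but differs elsewhere, gives a number close to compound 2, which gives no sign of a large shift. The step from compound 2 to compound 4 is therefore expected to be small, a 1.7-fold lower number from compound 2 to compound 4 (0.22 log units; within the scatter), not beyond the scatter in either direction. Compound 4 is expected to give about 3000 nM, within a range of 700 nM to 13000 nM.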

Compound 4, half-maximal effective concentration: 5000 nM
The estimate for compound 4 lay 1.7-fold (0.22 log units) below the measured number, within the range that was stated.
By their numbers in this assay, from the lowest: compound 1; then compounds 2, 4 and 3 (each within the scatter of the next).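

In this assay, going by these compounds alone, the exchange of the open 3-(dimethylamino)propyl chain for a (pyridin-3-yl)methyl group on the amine nitrogen gives no change at the digits printed from compound 2 to compound 4 (within the scatter) and is the first direct reading of a change at this position. On this core, a chain without a ring that ends in an amine and a six-membered aromatic ring with one hetero atom cannot be told apart by this read-out, even though the two groups differ in shape on paper. No measured property of these compounds bears on why the two groups give matching numbers, so the result stands without an explanation.

The comparison covers only these two groups on one core, so it cannot show whether this position tolerates changes in general. A plain phenyl ring with no nitrogen, a carboxylic acid at the end of the chain or a morpholine ring could each keep the number within the scatter or move it beyond, and no pair shown here tells which.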